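The source may hold more compounds than are shown below. What is called first, only, known or untested is meant among the compounds shown, and "the series" means these compounds.

Compound 1 `CN(c1ccn(C)n1)c1cnc(NCc2c(F)ccc3c2CCO3)c2cn[nH]c(=O)c12`: 62 mL.min-1.g-1. Compound 2 `O=C(Nc1ccccc1)c1cnc(NCc2c(F)ccc3c2CCO3)n2cnnc12`: 14 mL.min-1.g-1. Compound 3 `O=C1c2ccccc2CN1c1cnc(NCc2c(F)ccc3c2CCO3)n2cnnc12`: 13 mL.min-1.g-1.

In an ADME assay on microsomes from liver (Homo sapiens) for metabolic stability, read by LC-MS, using NADPH, with stated times of 5 min and 30 min, tested at 1 uM (on this read-out lower numbers stand for slow clearance and higher numbers for fast clearance), compound 1 stands highest of the three, with compound 2 and compound 3 both well beyond the scatter below it. Compound 4 `Cn1nccc1-c1cnc(NCc2c(F)ccc3c2CCO3)c2cn[nH]c(=O)c12` differs from compound 1 by 1-methyl-1H-pyrazol-5-yl in place of methyl(1-methyl-1H-pyrazol-3-yl)amino on an aromatic carbon. Among the compounds with values here, the only single-change step measured, a 1.1-fold lower number from compound 2 to compound 3 (0.03 log units; within the scatter), sits on a different core and at a different place, so it does not bear on this change; no measured pair tests the exchange of methyl(1-methyl-1H-pyrazol-3-yl)amino for 1-methyl-1H-pyrazol-5-yl. Compound 4 is therefore expected to stay close to compound 1, the estimated step being a 1.4-fold lower number from compound 1 to compound 4 (0.14 log units; within the scatter). The estimate for compound 4 is 45 mL.min-1.g-1, expected to fall between 15 mL.min-1.g-1 and 110 mL.min-1.g-1.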

Compound 4, intrinsic clearance in microsomes: 14 mL.min-1.g-1
Compound 4: the middle estimate sits 3.2-fold (0.51 log units) above what was measured; the measured number lies below the stated range.
By their numbers in this assay, from the lowest: compounds 3, 2 and 4 (each within the scatter of the next); then compound 1.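

In this assay this aromatic carbon of the shared core proves able to move the number: exchanging methyl(1-methyl-1H-pyrazol-3-yl)amino for 1-methyl-1H-pyrazol-5-yl gives a 4.4-fold lower number from compound 1 to compound 4 (0.65 log units; beyond the scatter). The high number of compound 1 therefore does not come with the core alone, but depends on the group at this place. Nothing measured here explains the fall.

From the compounds shown here alone, this single step changes both the amino link and the point of attachment on the pyrazole, so their separate contributions remain open. Going by these compounds, how a morpholine or a plain phenyl ring would stand on this carbon also remains open.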